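The source may hold more compounds than are shown below. What is called first, only, known or untested is meant among the compounds shown, and "the series" means these compounds.

Of the compounds shown here, three have so far been measured in an assay on COS-7 cells for inhibition of patatin-like phospholipase domain-containing protein 2 (Mus musculus); on this read-out lower numbers stand for stronger inhibition and higher numbers for weaker inhibition. Compound 1 `CCOC(=O)c1ccc(-c2ccc(OCC)cc2)s1` gives 70000 nM, compound 3 `CCOC(=O)c1cccc(-c2cccs2)c1` gives 90000 nM, and compound 2 `CCOC(=O)c1cccc(-c2ccc(OC)cc2)c1` gives 80000 nM. Compound 2 holds the second highest of the three numbers, yet its gap to compound 3 and its gap to compound 1 both lie within the scatter, so none of the three can be set above or below the others on these data. Compound 4 `CCOC(=O)c1cccc(-c2ccc(CN3CCCCC3)cc2)c1` has not yet been measured. It differs from compound 2 in one place: (piperidin-1-yl)methyl in place of methoxy on an aromatic carbon. Among the measured compounds shown here, no measured pair shows a change of this kind, so the data give no direct guide to its effect in this assay. Since all three measured compounds sit close together, a step of moderate size is expected, with a lean towards a lower number. The estimate for compound 4 in this assay is 40000 nM, with a range from 10000 nM to 120000 nM. The step thus expected is a 2.0-fold lower number from compound 2 to compound 4 (0.30 log units; within the scatter).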

Compound 4, half-maximal inhibitory concentration: 75000 nM
Compound 4: middle estimate off by 1.9-fold (0.27 log units), on the low side; measured number inside the range.
By their numbers in this assay, from the lowest: compounds 1, 4, 2 and 3 (each within the scatter of the next).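

In this assay, placing (piperidin-1-yl)methyl instead of methoxy on the aromatic carbon para to a large group gives a 1.1-fold lower number from compound 2 to compound 4 (0.03 log units; within the scatter), which lies within the scatter. Among the compounds shown here, this is the first step between measured compounds that differ in one place, and it shows that this position accepts the larger group, with its six-membered non-aromatic ring, without a change in the read-out beyond the scatter. Nothing measured here explains why the read-out holds across this change.

It remains open whether any group on this aromatic carbon can move the number beyond the scatter, as neither a carboxylic acid nor a primary amine stands there in the compounds shown. All of these compounds also keep the ethyl ester, so the effect of an amide or a carboxylic acid in its place is unknown.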